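This account rests on a few compounds, and the source may have more. Where it says the series, first, only, none or still open, it means among the compounds named here.

The measured compounds and their values:

Compound 1, `Cn1c(=O)c(C(=O)Nc2ccc(Oc3ccncc3-c3cccnc3)c(F)c2)nn(-c2ccc(Cl)cc2)c1=O`, gives 3220 nM.
Compound 2, `Cn1c(=O)c(C(=O)Nc2ccc(Oc3ccncc3-c3cccnc3)c(F)c2)nn(-c2cccc(C(F)(F)F)c2)c1=O`, gives 3980 nM.
Compound 3, `O=C(Nc1ccc(Oc2ccncc2-c2cccnc2)c(F)c1)c1ccnn(-c2ccc(Cl)cc2)c1=O`, gives 4840 nM.

These numbers come from a functional assay on MDA-MB-231 cells (Homo sapiens) for cytotoxicity, read by MTT assay, with a stated time of 72 h; a lower number here means a stronger inhibitor, a higher number a weaker inhibitor. Compound 3 has the highest of the three numbers, but its gaps to compound 2 and to compound 1 are both within the usual scatter, so no order can be read among them. Among the compounds with values here, the only measured step that changes the group on the aromatic nitrogen is a 1.2-fold higher number from compound 1 to compound 2 (0.09 log units; within the scatter), and it stayed within the scatter.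

Compound 4, `O=C(Nc1ccc(Oc2ccncc2-c2cccnc2)c(F)c1)c1ccnn(-c2ccc(F)cc2)c1=O`, differs from compound 3 by one change: fluoro in place of chloro on an aromatic carbon. Within the data shown here, no measured step swaps a chloro for a fluoro, so the closest guide is the step from compound 1 to compound 2, which showed that a change of the group on that nitrogen left the number essentially unmoved. The expected step in this assay is therefore a 1.0-fold higher number from compound 3 to compound 4 (0.01 log units; within the scatter), that is, none beyond the scatter. Compound 4 is estimated at 5000 nM, with a range from 2500 nM to 10000 nM.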

Compound 4, half-maximal inhibitory concentration: 5200 nM
Beside the measured number, compound 4's estimate is 1.0-fold (0.02 log units) below it; low and high end bracket the measured number.
By their numbers in this assay, from the lowest: compounds 1, 2, 3 and 4 (each within the scatter of the next).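

Going from 4-chlorophenyl to 4-fluorophenyl gives a 1.1-fold higher number from compound 3 to compound 4 (0.03 log units; within the scatter) in this assay. Within the data shown here, this is the first step that exchanges one halogen for another at a single spot on the ring, and it shows that this exchange, on the core of compound 3, does not shift the number beyond the scatter. Together with a 1.2-fold higher number from compound 1 to compound 2 (0.09 log units; within the scatter), which was read on a different core, it makes two changes to the group on the aromatic nitrogen that stay within the scatter, though nothing measured here offers an explanation for that.

On these data alone, both halogens are single atoms, so it remains open whether a very different group at this place, such as an amine, a carboxylic acid or a longer chain, would move the number. The compounds shown also leave open how far the other parts of the shared core contribute to the values in this assay.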